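From 4-methylphenyl to 2-methylphenyl on a shared core

The source may report more compounds than this note shows. Statements on the series, on what has been measured and on what is new or still open speak of the compounds shown alone.

Compound 1 `C[C@H]1CC[C@@H]2[C@@H](OC(=O)[C@]23CC(c2ccc(Cl)cc2)N(c2ccccc2)O3)[C@]2(C)C(=O)C=C[C@@]12O`: 3.87
Compound 2 `COc1ccc(C2C[C@@]3(ON2c2ccccc2)C(=O)O[C@@H]2[C@H]3CC[C@H](C)[C@]3(O)C=CC(=O)[C@@]23C)cc1`: 3.25
Compound 3 `Cc1ccc(C2C[C@@]3(ON2c2ccccc2)C(=O)O[C@@H]2[C@H]3CC[C@H](C)[C@]3(O)C=CC(=O)[C@@]23C)cc1`: 3.64

In a physicochemical assay for lipophilicity (on this read-out lower numbers stand for lower lipophilicity and higher numbers for higher lipophilicity), the picture around compound 3 is set by two steps: a number 0.23 log units lower from compound 1 to compound 3 (within the scatter) and a number 0.39 log units higher from compound 2 to compound 3 (beyond the scatter). Compound 4 `Cc1ccccc1C1C[C@@]2(ON1c1ccccc1)C(=O)O[C@@H]1[C@H]2CC[C@H](C)[C@]2(O)C=CC(=O)[C@@]12C` has the same atoms as compound 3, joined differently, with 2-methylphenyl in place of 4-methylphenyl on a saturated ring carbon. Within the data shown here, no measured step moves a group in this way. The nearest evidence comes from swaps of one group for another on an aromatic carbon: a number 0.62 log units lower from compound 1 to compound 2 (beyond the scatter) and a number 0.23 log units lower from compound 1 to compound 3 (within the scatter). Here no atoms are swapped, so no step beyond the scatter is expected in this assay. The estimated step is a number 0.04 log units lower from compound 3 to compound 4 (within the scatter). Compound 4 is expected at 3.6, with an estimated range of 3.2 to 4.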

Compound 4, partition coefficient: 3.64
Compound 4: the middle estimate sits 0.04 log units below what was measured; measured number inside the range.
By their numbers in this assay, from the lowest: compound 2; then compounds 3, 4 and 1 (each within the scatter of the next).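

In this assay, 2-methylphenyl in place of 4-methylphenyl gives no change at the digits printed from compound 3 to compound 4 (within the scatter), the first sign in this series that moving a group on this aryl ring, rather than swapping it, need not shift the number. The same aryl position also gives a number 0.39 log units higher from compound 2 to compound 4 (beyond the scatter) and a number 0.23 log units lower from compound 1 to compound 4 (within the scatter), so the 2-methylphenyl group stands as the 4-methylphenyl group did against both other compounds. Nothing measured here offers a reason for this. Still open, on these data alone, is whether an amine or a carboxylic acid on this ring would read alike when placed as in compound 4 rather than as in compound 3.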